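Replacing the carbamoyl group of compound 2

This account rests on a few compounds, and the source may have more. Where it says the series, first, only, none or still open, it means among the compounds named here.

Measured in a physicochemical assay for lipophilicity, at pH 7.4; on this read-out higher numbers stand for higher lipophilicity and lower numbers for lower lipophilicity:
- compound 1 `Cc1cc(C(N)=O)nn1Cc1cc(Cl)ccc1OCc1ccccc1`: 3.7
- compound 2 `Cc1cc(C(N)=O)nn1Cc1cc(Cl)ccc1OCC(C)C`: 3.1

Compound 2, at 3.1, holds the lower of the two numbers. Compound 3 `Cc1cc(NC(=O)C2CCCC2)nn1Cc1cc(Cl)ccc1OCC(C)C` keeps the rest of compound 2 and changes one group: (cyclopentylcarbonyl)amino in place of carbamoyl on an aromatic carbon. Put simply, this is (cyclopentylcarbonyl)amino in place of carbamoyl on an aromatic carbon. For the measured compounds named here, only one measured step offers any guide, and it comes from a different place in the molecule. That step is a number 0.60 log units lower from compound 1 to compound 2 (beyond the scatter), with isopropyl in place of phenyl, so the number fell as a smaller group replaced a larger one. The entering group here is the larger one, so a rise is expected in this assay, probably greater than that modest step. The estimated change is a number 1.20 log units higher from compound 2 to compound 3 (beyond the scatter). Compound 3 is expected at 4.3, within an estimated range of 3.7 to 4.9.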

Compound 3, distribution coefficient: > 3.7
Compound 3: only a limit was reported; the forecaster's own chance of this, stated with the estimate: 10%; the middle value does not contradict the limit.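

In this assay, compound 3 carries a limit of the assay rather than an exact number: the limit of > 3.7 in this assay, at which 1 of the 3 values shown sits. Even so, the step can be read as a number at least 0.60 log units higher from compound 2 to compound 3 (beyond the scatter), so the read-out also responds to a change on this aromatic carbon, not only to the earlier change on the saturated chain carbon bound to an oxygen. The counts of hydrogen-bond donors and acceptors are the same in carbamoyl and (cyclopentylcarbonyl)amino, so this swap adds carbon atoms and a non-aromatic ring without altering those counts.

On these data alone, the full size of the step remains unknown, and this single swap cannot separate the contribution of the cyclopentyl ring from that of the rest of the new group. As far as these compounds go, how a smaller acetylamino group, an amine or a carboxylic acid would read at this carbon also remains open.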